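The source may report more compounds than this note shows. Statements on the series, on what has been measured and on what is new or still open speak of the compounds shown alone.

Of the compounds shown here, three have been measured so far in a functional assay for inhibition of sodium/hydrogen exchanger (Oryctolagus cuniculus); a lower number here means a stronger inhibitor, a higher number a weaker inhibitor. Compound 1, `CS(=O)(=O)c1cc(C(=O)N=C(N)N)c(F)cc1F`, gives 630 nM. Compound 2, `Cc1c(C(=O)N=C(N)N)ccc(Cl)c1S(C)(=O)=O`, gives 1300 nM. Compound 3, `Cc1cc(-c2cc(Cl)cc(Cl)c2)c(S(C)(=O)=O)cc1C(=O)N=C(N)N`, gives 130 nM, the lowest of the three numbers; its gap to compound 1 and its wider gap to compound 2 both lie beyond the usual scatter of this assay, so on these numbers compound 3 is the strongest inhibitor of the set.

Compound 4, `Cc1cc(OC2CCCC2)c(S(C)(=O)=O)cc1C(=O)N=C(N)N`, has not yet been measured. It differs from compound 3 in a single place: cyclopentyloxy in place of 3,5-dichlorophenyl on an aromatic carbon. The entering group sits ortho to a methylsulfonyl group and para to a group of 6 heavy atoms, exactly where the leaving group stood.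

Among the measured compounds shown here, no pair of measured compounds differs in only one place, so nothing measured shows directly what this kind of swap does. The three measured numbers do show that changes around the shared core can move the result over a wide span, but they give no direction for this particular exchange. Compound 4 is estimated to give about 300 nM, with a range from 80 nM to 1200 nM. The expected step is a 2.3-fold higher number from compound 3 to compound 4 (0.36 log units; beyond the scatter), a weakening that may or may not reach beyond the scatter.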

Compound 4, half-maximal inhibitory concentration: 27 nM
Beside the measured number, compound 4's estimate is 11-fold (1.05 log units) above it, outside the stated range (below it).
By their numbers in this assay, from the lowest: compound 4; then compound 3; then compound 1; then compound 2.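

In this assay, putting cyclopentyloxy in place of 3,5-dichlorophenyl on this aromatic carbon gives a 4.8-fold lower number from compound 3 to compound 4 (0.68 log units; beyond the scatter), so at this position the 3,5-dichlorophenyl group is not needed to reach a low number, and a five-membered non-aromatic ring joined through oxygen does better here than the six-membered aromatic ring it replaces. Among the compounds shown here, this is the first direct reading of a single change, and it shows that this one position alone can shift the result by more than the usual scatter of repeated measurements. The swap changes several things at once, including the ring type, the loss of both chlorine atoms and the arrival of an oxygen atom, and nothing available shows which of these accounts for the lower number.

From the compounds shown here alone, it remains open whether the oxygen link matters in itself, which a cyclopentyl group joined directly to the aromatic carbon would help to settle. Also open, going by these compounds, is how an amine such as piperidine, or an open chain such as butoxy, would compare with cyclopentyloxy at this same place on the shared core.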